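From 3,5-dichlorobenzyl to 4-chlorobenzyl: working notes on the series

The source may hold more compounds than are shown below. What is called first, only, known or untested is meant among the compounds shown, and "the series" means these compounds.

Compound 1 (`CC1OC(=O)c2cc(C#N)c(N3CC(C(=O)NS(=O)(=O)Cc4ccccc4)C3)nc21`) gives > 300000 nM in a functional assay (Platelet, plasma) for inhibition, with Homo sapiens as the target (on this read-out lower numbers stand for stronger inhibition and higher numbers for weaker inhibition), and this is a limit of the assay, not a number. Compound 2 (`N#Cc1cc2c(nc1N1CCC(C(=O)NS(=O)(=O)Cc3ccccc3)CC1)CCC(F)C2=O`) gives 255000 nM in this assay as a true number. Compound 3 (`N#Cc1cc2c(nc1N1CCC(C(=O)NS(=O)(=O)Cc3cc(Cl)cc(Cl)c3)CC1)COC2=O`) gives 30500 nM in the same read-out. Compound 3 therefore holds the lower of the two true numbers, and its gap to compound 2 lies beyond the scatter.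

The next change leads from compound 3 to compound 4 (`N#Cc1cc2c(nc1N1CCC(C(=O)NS(=O)(=O)Cc3ccc(Cl)cc3)CC1)COC2=O`), with 4-chlorophenyl in place of 3,5-dichlorophenyl on a saturated chain carbon bound to a sulfonyl sulfur. Among the measured compounds shown here, no measured pair isolates this change, so the expectation starts from compound 3 at 30500 nM and carries a wide margin. A modest move towards weaker inhibition in this assay is expected, ending only slightly beyond the scatter. The estimated step is a 2.3-fold higher number from compound 3 to compound 4 (0.36 log units; beyond the scatter) and its direction is upward. For compound 4 the expected value is 70000 nM with an estimated range from 20000 nM to 250000 nM in this read-out.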

Compound 4, half-maximal inhibitory concentration: 4420 nM
Compound 4: the middle estimate sits 16-fold (1.20 log units) above what was measured; measured number below the stated range.
By their numbers in this assay, from the lowest: compound 4; then compound 3; then compound 2. At a limit, above all of these: compound 1.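

On the saturated chain carbon bound to a sulfonyl sulfur, the choice of aryl group clearly matters in this assay: the step of a 6.9-fold lower number from compound 3 to compound 4 (0.84 log units; beyond the scatter) is the only one in the series that can be read across a single change, as compound 1 and compound 2 differ from the others in more than one place. In this pair, 4-chlorophenyl gives the lower number despite carrying one chlorine fewer than 3,5-dichlorophenyl, so more chlorine on this ring does not go with stronger inhibition here. No measurement shown gives a reason for this step.

From the compounds shown here alone, it remains open whether the lower number comes from the chlorine kept in 4-chlorophenyl or from the loss of the 3,5-dichloro pattern, a question that a plain benzyl, 4-fluorobenzyl or 4-methoxybenzyl group on the core of compound 4 would help to settle. Also open, going by these compounds, is whether the same change holds on the core of compound 2, and whether a longer chain such as 2-phenylethyl fits at this place.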